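Swapping the Benzamide Substituent on Compound 3

A few compounds are considered here, and "the series" means these few. Any claim that something is new, unique, unknown or untested is made for them only; others in the source may bear on it.

The shared core is a naphthol bearing a sulfur-linked heterocycle and an amide; compound 1 `Cc1nnc(Sc2cc(NC(=O)c3ccc(Cl)cc3)c3ccccc3c2O)s1` carries a 5-methyl-1,3,4-thiadiazol-2-yl on that sulfur, while compound 3 `O=C(Nc1cc(Sc2ncn[nH]2)c(O)c2ccccc12)c1ccc(Cl)cc1` carries a 1H-1,2,4-triazol-5-yl there. In a functional assay on MDA-MB-231 cells (Homo sapiens) for antiproliferative activity, read by MTT assay, with a stated time of 48 h (on this read-out lower numbers stand for stronger inhibition and higher numbers for weaker inhibition), compound 1 reaches only the assay limit, > 100000 nM. Compound 2 `O=C(/C=C/c1ccc([N+](=O)[O-])cc1)Nc1cc(Sc2ncn[nH]2)c(O)c2ccccc12`, which also carries the triazole but a nitro-substituted cinnamide, likewise reaches only a limit in this assay, > 100000 nM. Among the compounds with values here, compound 3 gives 25700 nM in this assay, the only real number among the three, and the step of an at least 3.8-fold lower number from compound 1 to compound 3 (0.59 log units; beyond the scatter) shows the triazole outperforming the thiadiazole.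

Compound 4 `O=C(Nc1cc(Sc2ncn[nH]2)c(O)c2ccccc12)c1cccc([N+](=O)[O-])c1` is not yet measured. It differs from compound 3 in one place: 3-nitrophenyl in place of 4-chlorophenyl on a carbonyl carbon. Within the data shown here, no measured step touches that position, so the direction of change is unknown; the only other nitro-bearing compound, compound 2, sits at the limit (the limit of > 100000 nM in this assay, at which 2 of the 3 values shown sit), but it differs in more than one place. Compound 4 is therefore expected to land near compound 3, with a step of a 1.8-fold higher number from compound 3 to compound 4 (0.24 log units; within the scatter), at an estimated 45000 nM (range 12000 nM to 150000 nM).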

Compound 4, half-maximal inhibitory concentration: 48000 nM
For compound 4 the middle estimate is 1.1-fold (0.03 log units) below the measured one; the measured number falls inside the stated range.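

Within the data shown here, this is the first measured change at the aryl group on the carbonyl carbon, and in this assay it gives a 1.9-fold higher number from compound 3 to compound 4 (0.27 log units; within the scatter), so compound 3 and compound 4 cannot be told apart. At this level of resolution, the position accepts 3-nitrophenyl in place of 4-chlorophenyl without a detectable change in the read-out. Compound 4 also gives a real number, which shows that a nitro-bearing phenyl on this carbonyl carbon does not by itself send a compound to the assay limit.

Still open, on these data alone, is whether any other group here would give a number clearly lower than these two, such as a phenyl carrying an amine or a carboxylic acid, or a simple methyl in place of the ring. Real numbers remain scarce in this set: the limit of > 100000 nM in this assay, at which 2 of the 4 values shown sit.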